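Extending the alkyl on the benzimidazole: ethyl to propyl

This account rests on a few compounds, and the source may have more. Where it says the series, first, only, none or still open, it means among the compounds named here.

Of the compounds shown here, three sharing one core have been measured in an assay on membranes from HEK293 cells for displacement of a labelled ligand from Type-2 angiotensin II receptor (Homo sapiens), read by radioligand binding; a lower number here means a stronger inhibitor, a higher number a weaker inhibitor. Compound 1 `CCCCOC(=O)NS(=O)(=O)c1ccc(CCC)cc1-c1ccc(Cn2cnc3ccccc32)cc1` gives 29 nM. Compound 2 `CCCCOC(=O)NS(=O)(=O)c1ccc(CCC)cc1-c1ccc(Cn2c(C(C)(C)C)nc3ccccc32)cc1` gives 5.3 nM. Compound 3 `CCCCOC(=O)NS(=O)(=O)c1ccc(CCC)cc1-c1ccc(Cn2c(CC)nc3ccccc32)cc1` gives 11 nM, which places it second highest of the three numbers, with compound 2 nearest and compound 1 furthest. The new compound 4 `CCCCOC(=O)NS(=O)(=O)c1ccc(CCC)cc1-c1ccc(Cn2c(CCC)nc3ccccc32)cc1` differs from compound 3 by methyl in place of hydrogen on a saturated chain carbon, two bonds along the chain from an aromatic carbon.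

Among the measured compounds shown here, two measured steps bear on this change, both at the same aromatic carbon. Adding a small alkyl gave a 2.6-fold lower number from compound 1 to compound 3 (0.42 log units; beyond the scatter), and a larger alkyl gave a 5.5-fold lower number from compound 1 to compound 2 (0.74 log units; beyond the scatter); moving between the two alkyls gave a 2.1-fold higher number from compound 2 to compound 3 (0.32 log units; beyond the scatter). Each added carbon has so far been accompanied by a lower number, though the step between the two alkyls was the smallest of them. On that basis a modest further lowering in this assay is expected for compound 4, of about a 1.6-fold lower number from compound 3 to compound 4 (0.20 log units; within the scatter), with a real chance that it falls within the scatter. The estimate for compound 4 is 7 nM, within a range from 3.5 nM to 15 nM.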

Compound 4, inhibition constant: 14 nM
Estimate against measurement, compound 4: 2.0-fold (0.30 log units) below; low and high end bracket the measured number.
By their numbers in this assay, from the lowest: compound 2; then compounds 3 and 4 (each within the scatter of the next); then compound 1.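

In this assay, going from ethyl to propyl gives a 1.3-fold higher number from compound 3 to compound 4 (0.10 log units; within the scatter) and so no change that can be told from the scatter: the lower numbers that came with alkyl groups on this carbon do not carry on along the straight chain. Propyl keeps a 2.1-fold lower number from compound 1 to compound 4 (0.32 log units; beyond the scatter) but falls short of tert-butyl, with a 2.6-fold higher number from compound 2 to compound 4 (0.42 log units; beyond the scatter) in the same assay, so compound 2 stands apart from both straight-chain compounds. Nothing available gives a reason for these differences.

As far as these compounds go, whether a longer chain such as butyl would stay level with ethyl and propyl remains open. So does whether isopropyl, a smaller branched alkyl, would sit with compound 2 or with compound 3 and compound 4.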